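A methyl exchange at the limit of stability

The compounds below may be only part of what the source reports. "The series", "measured", "known", "first", "only" and "open" are said of these compounds alone.

Measured in an ADME assay on microsomes from liver (Rattus norvegicus) for metabolic stability; a lower number here means that the compound disappears faster, a higher number that the compound lasts longer:
compound 1 `Nc1nc(NCCNc2ncc(-c3ncc[nH]3)c(-c3ccccc3Br)n2)ccc1[N+](=O)[O-]`: > 0.5 h
compound 2 `Nc1nc(NCCNc2ncc(-c3ncc[nH]3)c(-c3ccc(Br)cc3F)n2)ccc1[N+](=O)[O-]`: > 0.5 h
compound 3 `Nc1nc(NCCNc2ncc(-c3ncc[nH]3)c(-c3cc(F)c(Cl)cc3F)n2)ccc1[N+](=O)[O-]`: > 0.5 h

Each of these values is a limit and not a number. Compound 3 gives > 0.5 h, which is a limit. The set as a whole shows (the limit of > 0.5 h in this assay, at which 3 of the 3 values shown sit).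

Compound 4 `Cc1cc(Cl)ccc1-c1nc(NCCNc2ccc([N+](=O)[O-])c(N)n2)ncc1-c1ncc[nH]1` carries 4-chloro-2-methylphenyl in place of 4-chloro-2,5-difluorophenyl on an aromatic carbon. The measured steps at this place are a step that the two limits leave unreadable from compound 1 to compound 2, a step that the two limits leave unreadable from compound 1 to compound 3 and a step that the two limits leave unreadable from compound 2 to compound 3. None of them gives a size or direction, so in this assay no step beyond the scatter is expected. The expected size is a step that the limit leaves unreadable from compound 3 to compound 4. Compound 4 is estimated at 0.7 h, within an expected range of 0.35 h to 1.5 h.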

Compound 4, half-life: > 0.5 h
Compound 4 was reported as a limit (the forecaster's own chance of this, stated with the estimate: 70%); the middle value is on the limit's open side.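

In this assay compound 4 gives > 0.5 h, which is a limit, so the steps to compound 4 from compound 1, compound 2 and compound 3 cannot be read. The actual half-lives of these compounds and their order remain open: the limit of > 0.5 h in this assay, at which 4 of the 4 values shown sit.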